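A few compounds are considered here, and "the series" means these few. Any claim that something is new, unique, unknown or untested is made for them only; others in the source may bear on it.

Compound 1 `CCCC(=O)Nc1c(C(O)(C(F)(F)F)C(F)(F)F)ccc2ccccc12` gives 131 nM in an assay on LtK cells with ATP-sensitive inward rectifier potassium channel 11 (Homo sapiens) as the target; a higher number here means that more compound is needed for the effect, a lower number that less compound is needed.
Compound 2 `O=C(Nc1c(C(O)(C(F)(F)F)C(F)(F)F)ccc2ccccc12)C1CCC1` gives 45 nM.

Within the data shown here, compound 2 stands lowest of these two numbers; the nearest is compound 1, and the only measured step is a 2.9-fold lower number from compound 1 to compound 2 (0.46 log units; beyond the scatter). Compound 3 `CC(C)OC(=O)Nc1c(C(O)(C(F)(F)F)C(F)(F)F)ccc2ccccc12` carries isopropoxy in place of cyclobutyl on a carbonyl carbon. That measured step exchanged one carbon-only group for another on the carbonyl carbon, whereas here isopropoxy replaces cyclobutyl, so it gives no direct guide to the direction. A change within the scatter, or at most a modest rise, is expected. For compound 3 the expected step is a 1.7-fold higher number from compound 2 to compound 3 (0.22 log units; within the scatter). Compound 3 is estimated at 75 nM, between 25 nM and 250 nM.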

Compound 3, half-maximal effective concentration: 1160 nM
For compound 3 the middle estimate is 15-fold (1.19 log units) below the measured one, and the stated range ends below it.
By their numbers in this assay, from the lowest: compound 2; then compound 1; then compound 3.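

Putting an oxygen-linked group on this carbonyl carbon costs far more than the earlier swap of one carbon-only group for another: there is a 26-fold higher number from compound 2 to compound 3 (1.41 log units; beyond the scatter), and an 8.9-fold higher number from compound 1 to compound 3 (0.95 log units; beyond the scatter). Both steps lie beyond the scatter, so in this assay the ring of cyclobutyl is not the whole story, since the ring-free propyl also gives a lower number than isopropoxy. Nothing at hand explains the size of this change. The compounds shown do not separate the effect of the oxygen from that of the branched shape of isopropoxy. Isobutyl or propoxy on the same carbonyl carbon would pull the two apart.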